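Chloro in place of hydrogen on the phenylcarbamoyl group

The source may hold more compounds than are shown below. What is called first, only, known or untested is meant among the compounds shown, and "the series" means these compounds.

The series holds two measured compounds. In a functional assay on KB cells (Homo sapiens) for inhibition, read by MTT assay, with a stated time of 24 h, tested at 100 ug/mL (on this read-out higher numbers stand for more inhibition of growth at the one concentration tested and lower numbers for less inhibition of growth), compound 1 (`O=C(O)CCCCC(CCSC(=O)c1ccccc1)SC(=O)c1ccccc1`) gives 89.8%. Compound 2 (`O=C(CCCCC(CCSC(=O)c1ccccc1)SC(=O)c1ccccc1)Nc1ccccc1`) is reported as "not active" (no number reported), so it has no single number and its standing rests on that description alone.

Compound 3 (`O=C(CCCCC(CCSC(=O)c1ccccc1)SC(=O)c1ccccc1)Nc1ccccc1Cl`) has yet to be measured. The structural change is chloro in place of hydrogen on an aromatic carbon, ortho to a large group: chloro in place of hydrogen on an aromatic carbon.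

Among the compounds with values here, no measured step in this assay covers this change, so its size can only be expected. A small upward step from the inactive compound 2, or none beyond the scatter, is expected, and another report without a number is quite possible. For compound 3, the estimated value is 15%, with an expected range of 0% to 40%.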

Compound 3, percent growth inhibition at one concentration: "not active" (no number reported)
The entry for compound 3 holds no number, so the estimate cannot be set against anything.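

In this assay compound 2 and compound 3 are both reported as not active, without a number, so no step can be read between them. The compounds shown leave open whether chloro in place of hydrogen changes growth inhibition at all. No evidence bears on this result.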